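Dropping One Chloro Group from Compound 1

This account rests on a few compounds, and the source may have more. Where it says the series, first, only, none or still open, it means among the compounds named here.

Compound 1 `ClCc1cccc(Cn2cnc3c(Cl)nc(Cl)nc32)c1`: 2290 nM
Compound 2 `ClCc1cccc(Cn2cnc3nc(Cl)nc(Cl)c32)c1`: 17000 nM
Compound 3 `ClCc1ccccc1Cn1cnc2c(Cl)nc(Cl)nc21`: 1540 nM

In a functional assay on IGROV-1 cells (Homo sapiens) for cytotoxicity, read by sulforhodamine B assay, with a stated time of 48 h (on this read-out higher numbers stand for weaker inhibition of growth and lower numbers for stronger inhibition of growth), compound 1 gives 2290 nM, the second highest of the three numbers. Compound 3 gives 1540 nM, which lies within the scatter of compound 1. Compound 2 gives 17000 nM, a higher number beyond the scatter. The unmeasured compound 4 `ClCc1cccc(Cn2cnc3c(Cl)ncnc32)c1` differs from compound 1 in one place: hydrogen in place of chloro on an aromatic carbon. Among the compounds with values here, no pair of measured compounds shows what this kind of change does, so the expectation rests on compound 1 alone. The step is expected to be a 1.7-fold higher number from compound 1 to compound 4 (0.24 log units; within the scatter), a modest move toward a higher number that could still fall within the scatter. Compound 4 is expected to give 4000 nM, between 1500 nM and 12000 nM.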

Compound 4, concentration for 50% growth inhibition: 9330 nM
Beside the measured number, compound 4's estimate is 2.3-fold (0.37 log units) below it; measured number inside the range.
By their numbers in this assay, from the lowest: compounds 3 and 1 (each within the scatter of the next); then compounds 4 and 2 (each within the scatter of the next).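

In this assay, hydrogen in place of chloro on the aromatic carbon between two ring nitrogen atoms gives a 4.1-fold higher number from compound 1 to compound 4 (0.61 log units; beyond the scatter) and so a step beyond the scatter. Within the data shown here, this is the first sign from a single change that this position matters for growth inhibition: without this chloro group, inhibition weakens. The data at hand give no reason for this step.

Hydrogen is the only replacement for this chloro group shown here. On these data alone, whether an amine or a methoxy group in the same place would hold the number of compound 1 remains open.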